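Asparagine-type side chain in place of isopropyl: compound 4

The compounds below may be only part of what the source reports. "The series", "measured", "known", "first", "only" and "open" are said of these compounds alone.

Measured so far:
compound 1, `C[C@@H](O)[C@H](NC(=O)CN(c1nc(Cl)nc2[nH]cnc12)C1CC1)C(=O)O`, 18.6% in a functional assay on the whole organism (Tail, strain ICR) with Mus musculus as the target, in the tail flick test, with a stated time of 30 min, at a dose of 25 umol/kg by the oral route; a higher number here means a stronger effect of the compound at the dose given, a lower number a weaker effect;
compound 2, `O=C(CN(c1nc(Cl)nc2[nH]cnc12)C1CC1)N[C@@H](CO)C(=O)O`, 38.7%;
compound 3, `CC(C)[C@H](NC(=O)CN(c1nc(Cl)nc2[nH]cnc12)C1CC1)C(=O)O`, 31.2%.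

Compound 3 stands second of the three numbers, with a number 7.5 percentage points lower from compound 2 to compound 3 (within the scatter) and a number 12.6 percentage points higher from compound 1 to compound 3 (beyond the scatter). Compound 4, `NC(=O)C[C@H](NC(=O)CN(c1nc(Cl)nc2[nH]cnc12)C1CC1)C(=O)O`, differs from compound 3 in one place: carbamoylmethyl in place of isopropyl on a saturated chain carbon bound to an amide-type nitrogen and a carbonyl carbon. The two steps that bear on this change are those into compound 3, where isopropyl replaced 1-hydroxyethyl and hydroxymethyl; one was modest and beyond the scatter, the other within it, and they point in opposite directions. With the same carbon now carrying carbamoylmethyl, the step of a number 3.2 percentage points lower from compound 3 to compound 4 (within the scatter) is expected to be small, not clearly beyond the scatter. Compound 4 is estimated at 28%, within 14% to 44%.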

Compound 4, a percentage reported as activity, at one dose (the size of the read-out at that dose, not a potency): 29.7%
Beside the measured number, compound 4's estimate is 1.7 percentage points below it; the range from low to high includes it.
By their numbers in this assay, from the lowest: compound 1; then compounds 4, 3 and 2 (each within the scatter of the next).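

In this assay carbamoylmethyl on the saturated chain carbon bound to an amide-type nitrogen and a carbonyl carbon reads the same as isopropyl (a number 1.5 percentage points lower from compound 3 to compound 4 (within the scatter)), so a chain with a hydrogen-bond donor and acceptor and a purely carbon chain are not told apart here. The step to the hydroxymethyl compound also stays small (a number 9 percentage points lower from compound 2 to compound 4 (within the scatter)). Only 1-hydroxyethyl stands apart (a number 11.1 percentage points higher from compound 1 to compound 4 (beyond the scatter)).

On these data alone, whether an amine, a carboxylic acid or a longer chain on this carbon would keep the number in the same range remains open. No evidence given here accounts for these steps.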